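The source may hold more compounds than are shown below. What is called first, only, known or untested is meant among the compounds shown, and "the series" means these compounds.

Three hydrazone-linked pyrazine carboxamides have been measured, and a fourth awaits its result. Compound 1 `O=C(N/N=C/c1cccc(O)c1)c1cnccn1` gives 100% in an ADME assay on J774 cells (Mus musculus) for cytotoxicity, read by MTT assay, with a stated time of 48 h, tested at 100 ug/mL; on this read-out higher numbers stand for a weaker effect at the one concentration tested and lower numbers for a stronger effect. Compound 3 `N#Cc1cccc(/C=N/NC(=O)c2cnccn2)c1` gives 100% in this assay. The two differ only by cyano in place of hydroxy on an aromatic carbon, and this change made no change at the digits printed from compound 1 to compound 3 (within the scatter). Compound 2 `O=C(N/N=C/c1ccc(O)cc1)c1cnccn1` is built from the same atoms as compound 1, joined differently; the difference between the two cores is not broken down here. In this assay compound 2 gives 81%, the lowest of the three numbers, lying beyond the scatter from both compound 1 and compound 3, so among these three it is the one with the stronger effect at the concentration tested.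

Compound 4 `N#Cc1ccc(/C=N/NC(=O)c2cnccn2)cc1` has not yet been measured. It is related to compound 2 by cyano in place of hydroxy on an aromatic carbon. Among the compounds with values here, this is the same kind of change as the one from compound 1 to compound 3, but not the same: there the cyano sits meta to a large group, here para to a large group. Within the data shown here, since that earlier change made no change at the digits printed from compound 1 to compound 3 (within the scatter), a step of similar small size is expected here, a number 5 percentage points higher from compound 2 to compound 4 (within the scatter), resting on the single measured pair alone. On this basis compound 4 is expected to give about 86% in this assay, plausibly between 70% and 100%.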

Compound 4, a percentage reported as activity, at one concentration (the size of the read-out at that concentration, not a potency): 100%
The estimate for compound 4 lay 14 percentage points below the measured number; measured number inside the range.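

In this assay, putting cyano in place of hydroxy on an aromatic carbon gave a number 19 percentage points higher from compound 2 to compound 4 (beyond the scatter), so the change did not carry over from the core of compound 1 to the core of compound 2 with the same result: the same change on two cores in this assay, no change at the digits printed (within the scatter) from compound 1 to compound 3 and a number 19 percentage points higher (beyond the scatter) from compound 2 to compound 4, 19 percentage points apart, beyond the scatter of two such steps

The printed values locate the difference among the hydroxy compounds, since compound 3 gives 100% and compound 4 gives 100%, while compound 1 gives 100% and compound 2 gives 81%. What this does not show is why the two steps part, or whether either would hold on a further core: the comparison rests on two pairs, read at one concentration, and gives no potency.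

The compounds shown leave open whether an amine or a carboxylic acid in place of the hydroxy of compound 2 would read like compound 2 or like compound 4 in this assay. They also leave open whether a methoxy group or a longer chain on that aromatic carbon would keep the stronger effect seen with compound 2, or whether that effect belongs to hydroxy alone among such groups.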